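Compound 3 against the inactive anilino pair

This account rests on a few compounds, and the source may have more. Where it says the series, first, only, none or still open, it means among the compounds named here.

Measured in a functional assay on U-937 cells (Homo sapiens) for cytotoxicity, read by MTT assay, with a stated time of 48 h; on this read-out higher numbers stand for weaker inhibition and lower numbers for stronger inhibition:
- compound 1 `Fc1ccc2nc(-c3ccccc3)nc(Nc3ccccc3)c2c1`: > 50000 nM (a limit)
- compound 2 `Fc1ccc(Nc2nc(-c3cccc(F)c3)nc3ccc(F)cc23)cc1`: > 50000 nM (a limit)

Among the measured compounds shown here, neither entry is a number, and the series so far stands at the limit of > 50000 nM in this assay, at which 2 of the 2 values shown sit. Compound 2 therefore has only a limit, > 50000 nM, and no measured potency.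

Compound 3 `Fc1cccc(-c2nc(Nc3ccccc3Cl)c3cc(F)ccc3n2)c1` carries a single change from compound 2: 2-chlorophenyl in place of 4-fluorophenyl on a nitrogen on an aromatic ring. In words, it has 2-chlorophenyl in place of 4-fluorophenyl on a nitrogen on an aromatic ring.

For the measured compounds named here, no measured step covers a swap at this nitrogen. Hence no step beyond the scatter is expected in this assay, and no direction is favoured. The expected change is a number no higher from compound 2 to compound 3 (the limit leaves the size open). Compound 3 is estimated at 50000 nM, with an expected range of 20000 nM to 100000 nM.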

Compound 3, half-maximal inhibitory concentration: > 50000 nM
Compound 3 gave a limit, no number; the forecaster's own chance of this, stated with the estimate: 70%; the middle value sits exactly at the limit.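

Compound 2 and compound 3 both give only limits in this assay, so no step can be read between them: the limit of > 50000 nM in this assay, at which 3 of the 3 values shown sit.

The compounds shown leave open whether any group on this nitrogen gives a number rather than a limit.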